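The source may hold more compounds than are shown below. What is called first, only, known or untested is meant among the compounds shown, and "the series" means these compounds.

Measured in a functional assay on HCT-116 cells (Homo sapiens) for antiproliferative activity, read by MTT assay, with a stated time of 24 h; a lower number here means a stronger inhibitor, a higher number a weaker inhibitor:
- Compound 1 `C=CCOc1ccc2c(=O)c(-c3cc(OC)c(OC)cc3OC)coc2c1`: 6600 nM
- Compound 2 `COc1cc(OC)c(-c2coc3cc(OCc4ccc([N+](=O)[O-])cc4)ccc3c2=O)cc1OC`: > 10000 nM (a limit of the assay, not a number)
- Compound 3 `COc1cc(OC)c(-c2coc3cc(OCc4ccc(Cl)cc4)ccc3c2=O)cc1OC`: 4450 nM

Compound 3 stands level with compound 1 within the scatter, as a 1.5-fold lower number from compound 1 to compound 3 (0.17 log units; within the scatter) shows. It stands clearly apart from compound 2 only in an at least 2.2-fold lower number from compound 2 to compound 3 (0.35 log units; beyond the scatter).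

Compound 4 `COc1cc(OC)c(-c2coc3cc(OCc4ccccc4Br)ccc3c2=O)cc1OC` carries 2-bromophenyl in place of 4-chlorophenyl on a saturated chain carbon bound to an oxygen on an aromatic ring.

The measured steps at this place are few. Vinyl to 4-chlorophenyl gave a 1.5-fold lower number from compound 1 to compound 3 (0.17 log units; within the scatter). Vinyl to 4-nitrophenyl gave an at least 1.5-fold higher number from compound 1 to compound 2 (0.18 log units; that floor lies within the scatter). Only the nitro to chloro change is beyond the scatter, and its size rests on a limit. Among the compounds with values here, no measured compound carries 2-bromophenyl, so the series gives no direct reading of this change.

With the step in compound 3 from a 1.5-fold lower number from compound 1 to compound 3 (0.17 log units; within the scatter) as the closest guide, no shift beyond the scatter is expected in this assay. A reading at the assay limit remains possible for compound 4, as seen for compound 2.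

The expected step is a 1.1-fold higher number from compound 3 to compound 4 (0.05 log units; within the scatter).

Compound 4 is expected at 5000 nM, with an estimated range of 2200 nM to 10000 nM.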

Compound 4, half-maximal inhibitory concentration: 4550 nM
Compound 4: the middle estimate sits 1.1-fold (0.04 log units) above what was measured, within the range that was stated.
By their numbers in this assay, from the lowest: compounds 3, 4 and 1 (each within the scatter of the next). At a limit, above all of these: compound 2.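

In this assay, 2-bromophenyl in place of 4-chlorophenyl on a saturated chain carbon bound to an oxygen on an aromatic ring leaves the reading level, at a 1.0-fold higher number from compound 3 to compound 4 (0.01 log units; within the scatter), so a second halogen-bearing phenyl now reads alike at this position. Set against the vinyl end group, the 2-bromophenyl group also stays within the scatter, at a 1.5-fold lower number from compound 1 to compound 4 (0.16 log units; within the scatter), which places compound 1, compound 3 and compound 4 together as one level group in this assay. The 4-nitrophenyl group remains the only one set apart, now against both halogen-bearing groups, at an at least 2.1-fold lower number from compound 2 to compound 4 (0.34 log units; beyond the scatter), and the size of that step rests on a limit of the assay rather than a number: the limit of > 10000 nM in this assay, at which 1 of the 4 values shown sits.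

The step to compound 4 changes the halogen and its place on the phenyl ring together, so the two changes cannot be separated here, and 4-bromophenyl or 2-chlorophenyl would be needed to read each alone. As far as these compounds go, how an amine or a carboxylic acid on the phenyl ring, or a longer chain in place of the benzyl group, would read in this assay remains open.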